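The compounds below may be only part of what the source reports. "The series", "measured", "known", "first", "only" and "open" are said of these compounds alone.

Measured so far in an assay on Ltk cells with metabotropic glutamate receptor 5 (Homo sapiens) as the target, read by fluorescence and calcium flux; a lower number here means a stronger inhibitor, a higher number a weaker inhibitor:
compound 1 `CCOc1cccnc1Nc1cccc(C)n1` gives 40 nM
compound 2 `COc1cccnc1Nc1cccc(C)n1` gives 458 nM
compound 3 `Cc1cccc(Nc2ncccc2OC(C)C)n1` gives 1000 nM

Compound 3 stands highest of the three in this assay: its nearest neighbour is compound 2, separated by a 2.2-fold higher number from compound 2 to compound 3 (0.34 log units; beyond the scatter), and the furthest is compound 1, separated by a 25-fold higher number from compound 1 to compound 3 (1.40 log units; beyond the scatter). The step to compound 4 `CCNc1cccnc1Nc1cccc(C)n1` is ethylamino in place of isopropoxy on an aromatic carbon.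

For the measured compounds named here, none of the measured steps exchanges the oxygen at this aromatic carbon for a nitrogen, so that part of the change has no precedent. What the measured steps do show is that the group on this carbon sets the number: an 11-fold higher number from compound 1 to compound 2 (1.06 log units; beyond the scatter), a 25-fold higher number from compound 1 to compound 3 (1.40 log units; beyond the scatter) and a 2.2-fold higher number from compound 2 to compound 3 (0.34 log units; beyond the scatter), all beyond the scatter. Of the three groups, the ethoxy of compound 1 gives the lowest number and the isopropoxy of compound 3 the highest. Compound 4 carries an ethyl chain again, now on a nitrogen that also brings a hydrogen-bond donor; the direction of the oxygen-to-nitrogen exchange itself is not fixed by any measured pair. Going by the values given here, the expectation is therefore a step down from compound 3 in this assay of about a 6.7-fold lower number from compound 3 to compound 4 (0.82 log units; beyond the scatter), with a wide range because a 25-fold higher number from compound 1 to compound 3 (1.40 log units; beyond the scatter) is the only guide to the chain part of the change. Compound 4 is estimated at 150 nM, in the range 30 nM to 800 nM.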

Compound 4, half-maximal inhibitory concentration: 3000 nM
The estimate for compound 4 lay 20-fold (1.30 log units) below the measured number; the measured number lies above the stated range.
By their numbers in this assay, from the lowest: compound 1; then compound 2; then compound 3; then compound 4.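

In this assay the exchange of oxygen for nitrogen at this aromatic carbon now has measured pairs, and the one that keeps the ethyl chain is the largest step in the series (the ethylamino in place of ethoxy change, a 75-fold higher number from compound 1 to compound 4 (1.88 log units; beyond the scatter)). The low number of compound 1 therefore does not follow from the ethyl chain alone: among the compounds shown it holds only with the oxygen in place, and ethylamino also stands above the two other alkoxy groups (against methoxy, a 6.6-fold higher number from compound 2 to compound 4 (0.82 log units; beyond the scatter); against isopropoxy, a 3.0-fold higher number from compound 3 to compound 4 (0.48 log units; beyond the scatter)). No supporting measurement is available to explain why the number rises with this exchange.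

Whether the low number stays with ethoxy alone is open, and a propoxy or cyclopropylmethoxy group at this carbon would test that. On the nitrogen side, the unsubstituted amine, methylamino and dimethylamino would show whether any group attached through nitrogen here can approach compound 1, and whether the amine hydrogen has any bearing on the rise.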